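One Methoxy Added Twice: Expecting Compound 4

The source may hold more compounds than are shown below. What is called first, only, known or untested is meant among the compounds shown, and "the series" means these compounds.

Of the compounds shown here, three have been measured in a functional assay on SK-MEL-5 cells (Homo sapiens) for cytotoxicity, read by sulforhodamine B assay, with a stated time of 48 h, tested at 10 uM; on this read-out lower numbers stand for a stronger effect and higher numbers for a weaker effect at the one concentration tested. Compound 3 `COc1ccc(-c2cc(/C=C/C(=O)c3ccc(N)cc3)[nH]n2)cc1OC` gives 6%. Compound 1 `COc1cc(-c2cc(/C=C/C(=O)c3ccc(N)cc3)[nH]n2)cc(OC)c1OC` gives -95% in this assay. The change from compound 3 to compound 1 is methoxy in place of hydrogen on an aromatic carbon, and it made a large step: a number 101 percentage points lower from compound 3 to compound 1 (beyond the scatter). Compound 2 `COc1ccc(C(=O)/C=C/c2cc(-c3cc(OC)c(OC)c(OC)c3)n[nH]2)cc1OC` gives -98% in this assay; the step of a number 3 percentage points lower from compound 1 to compound 2 (within the scatter) lies within the scatter. The difference between the cores of compound 2 and compound 3 is not broken down here.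

Compound 4 `COc1cc(C(=O)/C=C/c2cc(-c3cc(OC)c(OC)c(OC)c3)n[nH]2)cc(OC)c1OC` has not yet been measured. It differs from compound 2 by methoxy in place of hydrogen on an aromatic carbon, the same change as that from compound 3 to compound 1, with the surroundings of the place described in the same words. That earlier change made a large step, but it started from compound 3, whose read-out sits near zero. Because compound 2 gives -98% there is little room left downward on this percentage read-out, so the step is expected to be small: a number 1 percentage points lower from compound 2 to compound 4 (within the scatter). Compound 4 is estimated at -99%, expected to fall between -106% and -88%.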

Compound 4, a percentage reported as activity, at one concentration (the size of the read-out at that concentration, not a potency): -98%
Beside the measured number, compound 4's estimate is 1 percentage points below it, within the range that was stated.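

In this assay, the change of methoxy in place of hydrogen on an aromatic carbon did not carry the same size of step from one core to the other: the same change on two cores in this assay, a number 101 percentage points lower (beyond the scatter) from compound 3 to compound 1 and no change at the digits printed (within the scatter) from compound 2 to compound 4, 101 percentage points apart, beyond the scatter of two such steps. On the second core, the change gave no change at the digits printed from compound 2 to compound 4 (within the scatter). This does not show that the methoxy is without effect on that core, or that the size of the step follows a rule across the series: compound 2 already gives -98%, and a single tested concentration cannot separate compounds that read alike at that level.

The compounds shown leave open whether a lower concentration or measurements across a range of concentrations would tell compound 2 and compound 4 apart. They also leave open whether another group in the same place, such as a hydroxyl, a fluorine or a longer alkoxy chain, would give steps of different size on the two cores.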